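Chain Lengthening of an Ester Tail and Cytotoxicity

This account rests on a few compounds, and the source may have more. Where it says the series, first, only, none or still open, it means among the compounds named here.

Compound 1 `CCCCOC(=O)CCC(=O)N1CCN(CCCOc2cc3c(Nc4ccc(F)c(Cl)c4)ncnc3cc2OC)CC1` was examined in a functional assay on A549 cells (Homo sapiens) for cytotoxicity, read by MTT assay, with a stated time of 24 h, tested at 10 uM (on this read-out higher numbers stand for a weaker effect at the one concentration tested and lower numbers for a stronger effect), where compound 1 gives 94.4%. Compound 2 `CCCCCOC(=O)CCC(=O)N1CCN(CCCOc2cc3c(Nc4ccc(F)c(Cl)c4)ncnc3cc2OC)CC1` differs from it by methyl in place of hydrogen on a saturated chain carbon, four bonds along the chain from an oxygen next to a carbonyl group, and in this assay compound 2 gives 87.1%, a step of a number 7.3 percentage points lower from compound 1 to compound 2 (within the scatter). Compound 3 `CCCCCCCCCCCCCCCCCCOC(=O)CCC(=O)N1CCN(CCCOc2cc3c(Nc4ccc(F)c(Cl)c4)ncnc3cc2OC)CC1` carries a far longer ester tail; the difference between the two cores is not broken down here. In this assay compound 3 gives 94.8%. Compound 4 `CCCCCCCCCCCCCCCCCCCOC(=O)CCC(=O)N1CCN(CCCOc2cc3c(Nc4ccc(F)c(Cl)c4)ncnc3cc2OC)CC1` awaits measurement and differs from compound 3 by methyl in place of hydrogen on a saturated chain carbon, ten or more bonds along the chain from an oxygen next to a carbonyl group, the same kind of change as between compound 1 and compound 2, though at a different place along the chain. Because the earlier step of a number 7.3 percentage points lower from compound 1 to compound 2 (within the scatter) lay within the scatter, compound 4 is expected to shift only slightly, by a number 2.8 percentage points lower from compound 3 to compound 4 (within the scatter). Compound 4 is therefore estimated at 92%, between 82% and 100%.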

Compound 4, a percentage reported as activity, at one concentration (the size of the read-out at that concentration, not a potency): 94.5%
Beside the measured number, compound 4's estimate is 2.5 percentage points below it, and the stated range covers the measured number.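

In this assay, methyl in place of hydrogen on a saturated chain carbon, ten or more bonds along the chain from an oxygen next to a carbonyl group, gives a number 0.3 percentage points lower from compound 3 to compound 4 (within the scatter). Set beside the earlier step, the change behaves alike on the two cores, with no difference that can be told apart: the same change on two cores in this assay, a number 7.3 percentage points lower (within the scatter) from compound 1 to compound 2 and a number 0.3 percentage points lower (within the scatter) from compound 3 to compound 4, 7 percentage points apart, within the scatter of two such steps This shows that neither step stands out from the scatter, but it does not show that the change is without effect, for a small shift would go unseen and only one concentration was read.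

The compounds shown leave open how ester tails of intermediate length behave. They also leave open whether a tail ending in an amine or a carboxylic acid would read differently in this assay.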